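The compounds below may be only part of what the source reports. "The series", "measured", "known", "first", "only" and "open" are said of these compounds alone.

The measured compounds are compound 1 `CCCCCCCNC(=O)[C@H]1OC(n2cnc3c(N)ncnc32)[C@H](O)[C@@H]1O`, compound 2 `CCCCCCCCCCCCNC(=O)[C@H]1OC(n2cnc3c(N)ncnc32)[C@H](O)[C@@H]1O` and compound 3 `CC(=O)NCCCCCCCCNC(=O)[C@H]1OC(n2cnc3c(N)ncnc32)[C@H](O)[C@@H]1O`. In an assay on cell membranes for binding affinity to 2-oxoglutarate receptor 1 (Rattus norvegicus), read by radioligand binding (a higher number here means a weaker inhibitor, a lower number a stronger inhibitor), compound 1 gives 20 nM, compound 2 gives 163 nM and compound 3 gives 10 nM.

Compound 1 stands second highest of the three numbers in this assay. Its nearest neighbour is compound 3, reached by a 2.0-fold lower number from compound 1 to compound 3 (0.30 log units; within the scatter), and its furthest is compound 2, reached by an 8.2-fold higher number from compound 1 to compound 2 (0.91 log units; beyond the scatter). Between compound 2 and compound 3 the data show a 16-fold lower number from compound 2 to compound 3 (1.21 log units; beyond the scatter).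

Compound 4 `Nc1ncnc2c1ncn2C1O[C@H](C(=O)NC2CCCCCC2)[C@@H](O)[C@H]1O` differs from compound 1 by cycloheptyl in place of heptyl on an amide-type nitrogen. For the measured compounds named here, none of the measured steps changes a chain into a ring; the two steps that start from compound 1 instead lengthen or cap the chain at a carbon seven bonds along from the amide-type nitrogen, and only the lengthening in an 8.2-fold higher number from compound 1 to compound 2 (0.91 log units; beyond the scatter) went beyond the scatter. The change to compound 4 keeps the count of seven carbon atoms and adds no donor or acceptor, so nothing in the data points to a step beyond the scatter in this assay, in either direction.

Compound 4 is therefore estimated at 30 nM, with a range from 8 nM to 110 nM, which means an expected step of a 1.5-fold higher number from compound 1 to compound 4 (0.18 log units; within the scatter).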

Compound 4, inhibition constant: 22 nM
Beside the measured number, compound 4's estimate is 1.4-fold (0.13 log units) above it; measured number inside the range.
By their numbers in this assay, from the lowest: compounds 3, 1 and 4 (each within the scatter of the next, the first and the last beyond it); then compound 2.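

The earlier steps shown here altered the chain only far out along its length, whereas this one replaces the whole heptyl on the amide-type nitrogen with cycloheptyl, and a 1.1-fold higher number from compound 1 to compound 4 (0.04 log units; within the scatter) is what this assay records for that exchange. Among these compounds, then, an open chain on this nitrogen is not required for a number at the level of compound 1, since a seven-membered non-aromatic ring of carbon only gives a value that cannot be told apart from that of the heptyl compound. No measurement shown here accounts for this result.

The compounds shown leave open whether this tolerance extends to other rings on the same nitrogen, such as cyclopentyl, cyclohexyl, phenyl or a ring of carbon carrying a hydroxyl or an amine. They also leave open whether cycloheptyl would still match heptyl once a linker bearing an acetamido group or a carboxylic acid is attached to the ring, and whether a ring reached through a short methylene link would behave like one placed directly on the nitrogen.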